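Swapping a Silicon Group for a Hydroxyethyl Chain

The compounds below may be only part of what the source reports. "The series", "measured", "known", "first", "only" and "open" are said of these compounds alone.

Of the compounds shown here, three sharing one core have been tested in a functional assay on MCF7 cells (Homo sapiens) for antiproliferative activity, read by MTT assay, with a stated time of 72 h; a higher number here means a weaker inhibitor, a lower number a stronger inhibitor. Compound 1 `CC(C)(C)c1cn(C[C@H](O)[C@H]2OC(=O)C(OCc3ccccc3)=C2OCc2ccccc2)nn1` gives 730 nM, compound 2 `O=C1O[C@H]([C@@H](O)Cn2cc(CNS(=O)(=O)c3ccc(Cl)cc3F)nn2)C(OCc2ccccc2)=C1OCc1ccccc1` gives 3390 nM, and compound 3 `C[Si](C)(C)c1cn(C[C@H](O)[C@H]2OC(=O)C(OCc3ccccc3)=C2OCc2ccccc2)nn1` gives 12100 nM. Compound 3 stands highest of the three, that is, it is the weakest inhibitor here; compound 2 is nearest to it and compound 1 furthest. Among the measured compounds shown here, the one single-point step among the measured compounds, a 17-fold higher number from compound 1 to compound 3 (1.22 log units; beyond the scatter), shows that exchanging the group on this aromatic carbon can move the number a long way.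

Compound 4 `O=C1O[C@H]([C@@H](O)Cn2cc(CCO)nn2)C(OCc2ccccc2)=C1OCc1ccccc1` is the next step from compound 3: a group of 3 heavy atoms (2 carbon, 1 oxygen; no ring) in place of a group of 4 heavy atoms (3 carbon, 1 silicon; no ring), on an aromatic carbon. For the measured compounds named here, no measured pair makes exactly this exchange, so the size of the effect is uncertain. Since the group entering is small and carries a hydroxyl, and since the step from compound 1 to compound 3 was large, compound 4 is expected to come out lower than compound 3 in this assay, by roughly a 4.0-fold lower number from compound 3 to compound 4 (0.61 log units; beyond the scatter), with an estimated value of 3000 nM and a likely range from 800 nM to 12000 nM.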

Compound 4, half-maximal inhibitory concentration: 63400 nM
For compound 4 the middle estimate is 21-fold (1.32 log units) below the measured one; measured number outside the range, above it.
By their numbers in this assay, from the lowest: compound 1; then compound 2; then compound 3; then compound 4.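

In this assay, replacing the silicon-bearing group with 2-hydroxyethyl on this aromatic carbon gives a 5.2-fold higher number from compound 3 to compound 4 (0.72 log units; beyond the scatter), so a smaller group ending in a hydroxyl does not restore activity here but takes it further away. The same group in place of tert-butyl gives an 87-fold higher number from compound 1 to compound 4 (1.94 log units; beyond the scatter), and shortening the sulfonamide-bearing side chain of compound 2 to this hydroxyl-ended chain gives a 19-fold higher number from compound 2 to compound 4 (1.27 log units; beyond the scatter), which makes compound 4 the weakest of the four and shows that this position tolerates some groups far better than others. Nothing available here explains why this change lowers activity so much.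

On these data alone, it remains open whether the hydroxyl or the chain itself matters most. A plain ethyl group, a methoxyethyl group or a 2-aminoethyl group at this position would help separate the two.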